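Fluoro to methoxy on the triazole-linked phenyl of compound 2

A few compounds are considered here, and "the series" means these few. Any claim that something is new, unique, unknown or untested is made for them only; others in the source may bear on it.

Compound 1 `CC1(C)[C@H]2CC[C@]1(C)N(Cc1cn(-c3cccc(C#N)c3)nn1)C(=O)C2` gives 320 nM in a functional assay on LoVo cells (Homo sapiens) for inhibition, read by MTT assay, with a stated time of 24 h; a lower number here means a stronger inhibitor, a higher number a weaker inhibitor. Compound 2 `CC1(C)[C@H]2CC[C@]1(C)N(Cc1cn(-c3ccc(F)cc3)nn1)C(=O)C2` gives 40 nM in this assay.

Compound 2 stands lowest of the two numbers shown; its only neighbour is compound 1, with the step of an 8.0-fold lower number from compound 1 to compound 2 (0.90 log units; beyond the scatter). Compound 3 `COc1ccc(-n2cc(CN3C(=O)C[C@@H]4CC[C@@]3(C)C4(C)C)nn2)cc1` differs from compound 2 by methoxy in place of fluoro on an aromatic carbon, that is 4-fluorophenyl to 4-methoxyphenyl. Going by the values given here, no measured step touches that position: the one step known changes another group, so it gives no direct guide. Compound 3 is expected near compound 2, with at most a small step, a 1.8-fold higher number from compound 2 to compound 3 (0.24 log units; within the scatter), in the weaker direction. The estimate for compound 3 is 70 nM, range 25 nM to 250 nM.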

Compound 3, half-maximal inhibitory concentration: 70 nM
Beside the measured number, compound 3's estimate shows no gap at the digits printed; measured number inside the range.
By their numbers in this assay, from the lowest: compounds 2 and 3 (each within the scatter of the next); then compound 1.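

Methoxy and fluoro read alike at this position in this assay (a 1.8-fold higher number from compound 2 to compound 3 (0.24 log units; within the scatter)), so this position of the phenyl accepts either group with no change beyond the scatter. The step from the nitrile-bearing aryl group also holds for 4-methoxyphenyl (a 4.6-fold lower number from compound 1 to compound 3 (0.66 log units; beyond the scatter)), so compound 2 is not alone in reading below compound 1. No evidence on the cause of these readings is available.

Open, from the compounds shown here alone, is whether an amine, a carboxylic acid or a longer chain such as ethoxy at this position would keep the number in this range. Also open, going by these compounds, is whether the gap to compound 1 follows the nitrile itself or its place on the ring.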